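Sulfonyl aryl exchange: from compound 2 to compound 4

The compounds below may be only part of what the source reports. "The series", "measured", "known", "first", "only" and "open" are said of these compounds alone.

In an ADME assay on microsomes from liver (Homo sapiens) for metabolic stability, tested at 2.5 uM (a higher number here means faster removal of the compound, a lower number slower removal), compound 1 `Cc1ccc(S(=O)(=O)c2cnc3cc(F)ccc3c2-c2ccc(F)cc2)cc1C` gives 9.25 mL/min. Compound 2 `COc1cccc(-c2c(S(=O)(=O)c3ccc(C)c(C)c3)cnc3cc(F)ccc23)c1` gives 8.78 mL/min, and compound 3 `COc1ccc(-c2c(S(=O)(=O)c3ccc(C)c(C)c3)cnc3cc(F)ccc23)cc1` gives 4.13 mL/min. Compound 2 thus stands second highest of the three numbers: the step of a 1.1-fold lower number from compound 1 to compound 2 (0.02 log units; within the scatter) lies within the scatter, while the steps of a 2.1-fold lower number from compound 2 to compound 3 (0.33 log units; beyond the scatter) and a 2.2-fold lower number from compound 1 to compound 3 (0.35 log units; beyond the scatter) both reach modest size.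

Compound 4 `COc1cccc(-c2c(S(=O)(=O)c3cc(Cl)cc(Cl)c3)cnc3cc(F)ccc23)c1` differs from compound 2 in one place: 3,5-dichlorophenyl in place of 3,4-dimethylphenyl on a sulfonyl sulfur. Every measured step in the set concerns the aryl that sits on the core, not the aryl on the sulfonyl sulfur, so none bears directly on this change. Among the compounds with values here, the three numbers span a narrow band, and the position now altered has no precedent among them, so the expectation rests on where compound 2 stands alone. For compound 4 the expected step is a 1.2-fold lower number from compound 2 to compound 4 (0.07 log units; within the scatter), judged likely to fall within or close to the scatter. For compound 4 the estimate in this assay is 7.5 mL/min, with a range from 3.5 mL/min to 16 mL/min kept wide to reflect the absence of any measured step at this position.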

Compound 4, intrinsic clearance in a liver preparation (reported as CLH), per the amount of preparation that the assay uses: 1.51 mL/min
Estimate against measurement, compound 4: 5.0-fold (0.70 log units) above; the measured number lies below the stated range.
By their numbers in this assay, from the lowest: compound 4; then compound 3; then compounds 2 and 1 (each within the scatter of the next).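

The aryl on the sulfonyl sulfur is a position that moves the number in this assay, and the exchange of 3,4-dimethylphenyl for 3,5-dichlorophenyl goes toward slower removal (a 5.8-fold lower number from compound 2 to compound 4 (0.76 log units; beyond the scatter)). This step is larger than any step among compound 1, compound 2 and compound 3, all of which concern the aryl on the core, and it arises although the two groups match in heavy atoms, in hydrogen-bond donors and acceptors, and in net charge as counted. Nothing at hand accounts for the step, so it stands as an observation on this one pair.

Still open, going by these compounds, is which part of the exchange carries the step: the chlorine atoms, the loss of the methyl groups or the altered substitution pattern, which a 3,4-dichlorophenyl or a 3,5-dimethylphenyl on the sulfonyl sulfur would help to separate. Also open, on these data alone, is whether the step holds with the aryl on the core of compound 1 or compound 3, and how an unsubstituted phenyl or a pyridyl would behave at the sulfonyl sulfur.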